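A Six-Membered Ring in Place of a Fused Bicycle

A few compounds are considered here, and "the series" means these few. Any claim that something is new, unique, unknown or untested is made for them only; others in the source may bear on it.

Compound 1 `CNC(=O)c1cc(C(=O)N[C@H]2[C@@H]3COC[C@@H]32)c([C@@H](C)c2ccccc2)o1` and compound 2 `CNC(=O)c1cc(C(=O)N[C@H]2[C@@H]3C[C@@H](O)C[C@@H]32)c([C@@H](C)c2ccccc2)o1` share one core and were both tested in an ADME assay on cells (Hepatocyte, Canis lupus familiaris) for metabolic stability, read by LC-MS; on this read-out lower numbers stand for slow clearance and higher numbers for fast clearance. In this assay compound 1 gives < 0.65 mL/min, which is a limit of the assay rather than a number. In this assay compound 2 gives < 0.65 mL/min, again a limit. The step that the two limits leave unreadable from compound 1 to compound 2 therefore cannot be read, and the only thing the two results show is the limit of < 0.65 mL/min in this assay, at which 2 of the 2 values shown sit. Compound 2 thus stands at the limit, with no measured number to place it more finely.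

Compound 3 `CNC(=O)c1cc(C(=O)N[C@H]2CC[C@H](O)CC2)c([C@@H](C)c2ccccc2)o1` has not yet been tested in this assay. It differs from compound 2 by a group of 7 heavy atoms (6 carbon, 1 oxygen; one six-membered non-aromatic ring of carbon only) in place of a group of 7 heavy atoms (6 carbon, 1 oxygen; one three-membered non-aromatic ring of carbon only, one five-membered non-aromatic ring of carbon only), on an amide-type nitrogen. No measured step bears directly on this change, and the single step shown is unreadable. Because compound 2 sits at the limit (the limit of < 0.65 mL/min in this assay, at which 2 of the 2 values shown sit), compound 3 is expected to stay close to it. The expected step that the limit leaves unreadable from compound 2 to compound 3 is estimated to be small. The estimate for compound 3 is 0.5 mL/min, with a range from 0.2 mL/min to 1.5 mL/min.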

Compound 3, intrinsic clearance in a liver preparation (reported as CLH), per the amount of preparation that the assay uses in the Hepatocyte assay: < 0.7 mL/min
Compound 3 was reported as a limit; the forecaster's own chance of this, stated with the estimate: 60%; the middle value is on the limit's open side.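

No new step can be read among compound 1, compound 2 and compound 3, as every result is a limit of its assay and not a number. In a physicochemical assay for solubility (on this read-out lower numbers stand for lower solubility and higher numbers for higher solubility), compound 2 gives >= 172 ug/mL, a limit. In the physicochemical assay compound 3 gives >= 184 ug/mL, also a limit. Where the actual numbers for compound 2 and compound 3 lie stays open in both assays.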